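This account rests on a few compounds, and the source may have more. Where it says the series, first, only, none or still open, it means among the compounds named here.

In an ADME assay on PC-3 cells (Homo sapiens) for cytotoxicity, read by sulforhodamine B assay, with a stated time of 48 h, tested at 10 uM (on this read-out lower numbers stand for less inhibition and higher numbers for more inhibition at the one concentration tested (going by the name of the read-out)), three related compounds have been measured. Compound 1 `CCCCCCCc1cn(C(c2ccccc2)c2cc3cc(Br)ccc3nc2OC)nn1` gives 4.42%, compound 2 `COc1nc2ccc(Br)cc2cc1C(c1ccccc1)n1cc(-c2ccccc2)nn1` gives 5.97%, and compound 3 `CCOC(=O)c1cn(C(c2ccccc2)c2cc3cc(Br)ccc3nc2OC)nn1` gives 16.1%. On these numbers compound 2 stands second highest of the three: its nearest neighbour is compound 1, whose value lies within the scatter of its own, and the furthest is compound 3, whose value lies beyond the scatter. The step of a number 1.6 percentage points higher from compound 1 to compound 2 (within the scatter) came with phenyl in place of heptyl on an aromatic carbon, whereas a number 11.7 percentage points higher from compound 1 to compound 3 (beyond the scatter) and a number 10.1 percentage points higher from compound 2 to compound 3 (beyond the scatter) each came with ethoxycarbonyl entering.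

Compound 4 `CCCc1cn(C(c2ccccc2)c2cc3cc(Br)ccc3nc2OC)nn1` differs from compound 2 in one place: propyl in place of phenyl on an aromatic carbon. Among the compounds with values here, the only measured step that bears on this swap is the one that put phenyl in place of heptyl, a number 1.6 percentage points higher from compound 1 to compound 2 (within the scatter), which stayed within the scatter; propyl, like heptyl, is a chain, and no other step here exchanges a chain for a ring. A step in this assay of no size beyond the scatter is therefore expected, a number 1 percentage points lower from compound 2 to compound 4 (within the scatter). Compound 4 is thus estimated at 5%, within a range from 0.5% to 12%.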

Compound 4, a percentage reported as inhibition, at one concentration (the size of the read-out at that concentration, not a potency): 8.3%
For compound 4 the middle estimate is 3.3 percentage points below the measured one; the measured number falls inside the stated range.
By their numbers in this assay, from the lowest: compounds 1, 2, 4 and 3 (each within the scatter of the next, the first and the last beyond it).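

In this assay phenyl, heptyl and propyl on this aromatic carbon of the five-membered ring cannot be told apart, as a number 2.3 percentage points higher from compound 2 to compound 4 (within the scatter) and a number 3.9 percentage points higher from compound 1 to compound 4 (within the scatter) both show. Ethoxycarbonyl stood clear of heptyl and phenyl, but it does not stand clear of propyl, with a number 7.8 percentage points lower from compound 3 to compound 4 (within the scatter), so the separation of compound 3 does not hold against every group tried at this position. Nothing measured here offers an explanation for these readings.

On these data alone, whether any group on this carbon could give a reading far beyond these four stays open, for instance a carboxylic acid, an amide or a chain ending in an amine. As far as these compounds go, it also stays open whether ethoxycarbonyl truly differs from the alkyl chains, given that compound 3 lies beyond the scatter of compound 1 but within that of compound 4.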